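Cyclopentylamino in place of 2-methoxyethoxy: expected cytotoxicity

The compounds below may be only part of what the source reports. "The series", "measured", "known", "first", "only" and "open" are said of these compounds alone.

Compound 1: `COCCOc1nc(N)nc2c1ncn2/C=C1/CC1(CO)CO` — > 300000 nM
Compound 2: `Nc1nc(OCc2ccccc2)c2ncn(/C=C3/CC3(CO)CO)c2n1` — > 300000 nM
Compound 3: `CC(C)Nc1nc(N)nc2c1ncn2/C=C1/CC1(CO)CO` — > 300000 nM

Of the compounds shown here, three share one core and have been tested in an ADME assay on HFF cells (Homo sapiens) for cytotoxicity, with a stated time of 8 days; on this read-out higher numbers stand for lower toxicity in this test and lower numbers for higher toxicity in this test. For compound 1 the reading is a limit of the assay, not a number. The same holds for compound 2, whose value is likewise a limit. Compound 3 also sits at a limit. Together this gives (the limit of > 300000 nM in this assay, at which 3 of the 3 values shown sit), so that no compound can be ranked against another.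

The steps among the measured compounds are accordingly unreadable: a step that the two limits leave unreadable from compound 1 to compound 2, a step that the two limits leave unreadable from compound 1 to compound 3 and a step that the two limits leave unreadable from compound 2 to compound 3.

The step in question leads from compound 1 to compound 4, `Nc1nc(NC2CCCC2)c2ncn(/C=C3/CC3(CO)CO)c2n1`. The change is cyclopentylamino in place of 2-methoxyethoxy on an aromatic carbon. Among the measured compounds shown here, the steps that bear on it are the three above, and none of them yields a size. Since every measured value rests at the limit because of the limit of > 300000 nM in this assay, at which 3 of the 3 values shown sit, the expectation in this assay is no step beyond the scatter, and most probably another limit. Compound 4 is therefore expected to give about 300000 nM, within a range from 150000 nM to 600000 nM. That estimate amounts to an expected step of a number no higher from compound 1 to compound 4 (the limit leaves the size open).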

Compound 4, half-maximal cytotoxic concentration: > 300000 nM
Compound 4 was reported as a limit; the forecaster's own chance of this, stated with the estimate: 85%; the middle value lies on the limit itself.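

In this assay compound 4 gives > 300000 nM, which is a limit of the assay. The steps to compound 4 from compound 1, compound 2 and compound 3 therefore cannot be read, as all four compounds share one reading: the limit of > 300000 nM in this assay, at which 4 of the 4 values shown sit.

The compounds shown leave open how these four rank against one another in this assay.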